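Notes on the anilide pair, compound 2 to compound 4

A few compounds are considered here, and "the series" means these few. Any claim that something is new, unique, unknown or untested is made for them only; others in the source may bear on it.

In an assay on isolated protein (Mus musculus) for inhibition of IL15-IL15 receptor (Homo sapiens), read by resazurin assay, with stated times of 30 min and 2.5 days (a lower number here means a stronger inhibitor, a higher number a weaker inhibitor), compound 1 `Cn1c(Cc2nn(C)c(=O)c3ccccc23)nnc1SCCCCCCCC(=O)Nc1ccc(Cl)cc1Cl` gives 1900 nM.
In this assay compound 2 `CN(C(=O)CSc1nnc(Cc2nn(C)c(=O)c3ccccc23)n1C)c1ccc(Cl)cc1Cl` reaches only the assay limit, > 30000 nM.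
In this assay compound 3 `CN(C(=O)CCCCCCCSc1nnc(Cc2nn(C)c(=O)c3ccccc23)n1C)c1ccc(Cl)cc1Cl` gives 11900 nM.

Compound 2 thus stands at the limit of this assay and has no number of its own, as the limit of > 30000 nM in this assay, at which 1 of the 3 values shown sits, records. Compound 4 `CC(C)Oc1ccc(NC(=O)CSc2nnc(Cc3nn(C)c(=O)c4ccccc34)n2C)cc1` differs from it by (4-isopropoxyphenyl)amino in place of (2,4-dichlorophenyl)(methyl)amino on a carbonyl carbon. Going by the values given here, the one measured step bearing on this is a 6.3-fold higher number from compound 1 to compound 3 (0.80 log units; beyond the scatter); the change from compound 2 to compound 4 runs in the opposite sense on the amide-type nitrogen, while the exchange of the aryl part has no measured counterpart. Compound 4 is therefore expected to give a readable number, estimated at 12000 nM (range 3000 nM to 40000 nM). That estimate means an at least 2.5-fold lower number from compound 2 to compound 4 (0.39 log units; beyond the scatter), expected to lie beyond the scatter, though anchored only on a limit.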

Compound 4, half-maximal inhibitory concentration: > 30000 nM
Compound 4: no number, only a limit (the forecaster's own chance of this, stated with the estimate: 35%); middle value at least 2.5-fold (0.39 log units) away from the limit.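

In this assay, compound 2 and compound 4 both stand only as limits, so no step between them can be read: the limit of > 30000 nM in this assay, at which 2 of the 4 values shown sit.

The compounds shown leave open whether (4-isopropoxyphenyl)amino and (2,4-dichlorophenyl)(methyl)amino on a carbonyl carbon differ in inhibition at all.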